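The source may report more compounds than this note shows. Statements on the series, on what has been measured and on what is new or still open speak of the compounds shown alone.

Measured in an assay on LtK cells with ATP-sensitive inward rectifier potassium channel 11 (Homo sapiens) as the target; a higher number here means that more compound is needed for the effect, a lower number that less compound is needed:
compound 1 `CCC(=O)Nc1c(C(O)(C(F)(F)F)C(F)(F)F)ccc2ccccc12` gives 15 nM
compound 2 `C/C=C/C(=O)Nc1c(C(O)(C(F)(F)F)C(F)(F)F)ccc2ccccc12` gives 72 nM
compound 3 `O=C(Nc1c(C(O)(C(F)(F)F)C(F)(F)F)ccc2ccccc12)c1cccc(Cl)c1` gives 98 nM

Compound 3 gives the highest of the three numbers in this assay; compound 2 lies within the scatter of it, while compound 1 sits further off, as the step of a 6.5-fold higher number from compound 1 to compound 3 (0.82 log units; beyond the scatter) shows. Compound 4 `Cc1cccc(C(=O)Nc2c(C(O)(C(F)(F)F)C(F)(F)F)ccc3ccccc23)c1` differs from compound 3 by methyl in place of chloro on an aromatic carbon. Going by the values given here, none of the measured steps alters a group on this ring; each exchanges the whole group on the carbonyl carbon: a 4.8-fold higher number from compound 1 to compound 2 (0.68 log units; beyond the scatter), a 6.5-fold higher number from compound 1 to compound 3 (0.82 log units; beyond the scatter) and a 1.4-fold higher number from compound 2 to compound 3 (0.13 log units; within the scatter). They give no guide to swapping one group for another on the ring, so no step beyond the scatter is expected in this assay. Compound 4 is therefore expected at 100 nM, with a range from 40 nM to 250 nM. That corresponds to an expected step of a 1.0-fold higher number from compound 3 to compound 4 (0.01 log units; within the scatter).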

Compound 4, half-maximal effective concentration: 23 nM
Beside the measured number, compound 4's estimate is 4.3-fold (0.64 log units) above it; measured number outside the range, below it.
By their numbers in this assay, from the lowest: compounds 1 and 4 (each within the scatter of the next); then compounds 2 and 3 (each within the scatter of the next).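

In this assay, this small exchange on the ring matters: going from 3-chlorophenyl to 3-methylphenyl gives a clear change (a 4.3-fold lower number from compound 3 to compound 4 (0.63 log units; beyond the scatter)), about as large as the earlier exchanges of the whole group on the carbonyl carbon. The 3-methylphenyl group also separates from prop-1-en-1-yl (a 3.1-fold lower number from compound 2 to compound 4 (0.50 log units; beyond the scatter)), yet stays level with ethyl (a 1.5-fold higher number from compound 1 to compound 4 (0.19 log units; within the scatter)), so a ring on the carbonyl carbon can match the lowest number seen. Nothing measured here explains why methyl and chloro differ. Going by these compounds, how a methoxy group, an amine or a carboxylic acid at this ring position would behave remains open.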